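Swapping bromine position on a thiazole hydrazone series

This account rests on a few compounds, and the source may have more. Where it says the series, first, only, none or still open, it means among the compounds named here.

Of the compounds shown here, three of a shared core have been tested in a functional assay on A549 cells (Homo sapiens) for inhibition, read by MTT assay, with a stated time of 48 h; a lower number here means a stronger inhibitor, a higher number a weaker inhibitor. Compound 1, `Fc1ccc(/C=N/Nc2nc(-c3cccc(Br)c3)cs2)cc1F`, gives 16200 nM in this assay. Compound 2, `Fc1ccc(/C=N/Nc2nc(-c3ccc(Br)cc3)cs2)cc1F`, differs from compound 1 by 4-bromophenyl in place of 3-bromophenyl on an aromatic carbon. In this assay compound 2 reaches only the limit of the measurement, > 100000 nM, and no number beyond it. The result is an at least 6.1-fold higher number from compound 1 to compound 2 (0.79 log units; beyond the scatter), and this step rests on (the limit of > 100000 nM in this assay, at which 1 of the 3 values shown sits).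

Compound 3, `COc1cc(/C=N/Nc2nc(-c3cccc(Br)c3)cs2)c(Br)c(Br)c1OC`, gives 37000 nM in this assay, the higher of the two numbers recorded so far, and the gap between compound 3 and compound 1 lies beyond the scatter. The difference between the core of compound 3 and the core of compound 1 is not broken down here.

Compound 4, `COc1cc(/C=N/Nc2nc(-c3ccc(Br)cc3)cs2)c(Br)c(Br)c1OC`, is not yet measured. For the measured compounds named here, it differs from compound 3 by 4-bromophenyl in place of 3-bromophenyl on an aromatic carbon, which is the same change as the one between compound 1 and compound 2, at the same place. Since compound 3 already starts from a higher number than compound 1, a step of similar size would carry compound 4 past the upper reach of this assay. The step from compound 3 to compound 4 is therefore expected to be a 4.1-fold higher number from compound 3 to compound 4 (0.61 log units; beyond the scatter), because the same change earlier produced an at least 6.1-fold higher number from compound 1 to compound 2 (0.79 log units; beyond the scatter). Compound 4 is expected to give about 150000 nM in this assay, with a range from 50000 nM to 500000 nM, and it is quite likely that only a limit will be reported.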

Compound 4, half-maximal inhibitory concentration: 46100 nM
Compound 4: the middle estimate sits 3.3-fold (0.51 log units) above what was measured, and the stated range ends above it.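

In this assay, the same swap of 3-bromophenyl for 4-bromophenyl that marked a clear difference on the core of compound 1 gives a 1.2-fold higher number from compound 3 to compound 4 (0.10 log units; within the scatter), so on the core of compound 3 the two bromine placements cannot be told apart. The effect of this change therefore does not carry over at the same size from one core to the other, and the result on one core is a poor guide to the result on the other: the same change on two cores in this assay, an at least 6.1-fold higher number (0.79 log units; beyond the scatter) from compound 1 to compound 2 and a 1.2-fold higher number (0.10 log units; within the scatter) from compound 3 to compound 4, at least 4.9-fold (0.69 log units) apart, beyond the scatter of two such steps Compound 2 is recorded only as a limit, > 100000 nM, so the full size of the first step stays unknown, and these compounds do not show which feature of the two cores makes the steps differ: the limit of > 100000 nM in this assay, at which 1 of the 4 values shown sits.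

With only two cores shown, it remains open which of them is the more typical case and how the same swap would behave on a third core. On these data alone, it is also open whether an amine or a carboxylic acid in place of the bromine on the phenyl group would separate the two placements on either core.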